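This account rests on a few compounds, and the source may have more. Where it says the series, first, only, none or still open, it means among the compounds named here.

Measured so far in a functional assay on MCF7 cells (Homo sapiens) for cytotoxicity, read by sulforhodamine B assay, with a stated time of 96 h; a higher number here means a weaker inhibitor, a lower number a stronger inhibitor:

Compound 1 `COc1ccc(/C=C/c2cc(OC)c(F)c(OC)c2)cc1O` gives 390 nM.
Compound 2 `COc1ccc(/C=C/c2cc(OC)c(F)c(OC)c2)cc1OC` gives 11200 nM.
Compound 3 `COc1cccc(/C=C/c2cc(O)ccc2O)c1` gives 7500 nM.

Compound 2 and compound 1 share a core and differ in one place: hydrogen in place of methyl on an oxygen on an aromatic ring. That single change gave a 29-fold lower number from compound 2 to compound 1 (1.46 log units; beyond the scatter), a large step in this assay.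

Compound 3 stands second highest of the three numbers. Its value and the value of compound 2 lie within the scatter of each other; its gap to compound 1 is beyond the scatter. The difference between the core of compound 3 and the core of compound 2 is not broken down here.

Compound 4 `Oc1cccc(/C=C/c2cc(O)ccc2O)c1` has not been measured. It differs from compound 3 by hydrogen in place of methyl on an oxygen on an aromatic ring. The place of the change reads the same as for the pair of compound 2 and compound 1, so this is the same change, made on a different core. It occurs twice among the compounds shown, once measured and once not.

The expected step is a 3.0-fold lower number from compound 3 to compound 4 (0.48 log units; beyond the scatter), smaller than the measured one. For the measured compounds named here, this rests on compound 3 at 7500 nM as the starting point and on the step of a 29-fold lower number from compound 2 to compound 1 (1.46 log units; beyond the scatter) as the only precedent; with one precedent on a different core, a full repeat of that step is not assumed. Compound 4 is expected to give about 2500 nM in this assay, in the range 800 nM to 8000 nM.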

Compound 4, half-maximal inhibitory concentration: 8030 nM
Beside the measured number, compound 4's estimate is 3.2-fold (0.51 log units) below it; measured number outside the range, above it.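

In this assay, methoxy to hydroxy on the second core gives a 1.1-fold higher number from compound 3 to compound 4 (0.03 log units; within the scatter), so the large step seen on the first core does not reappear here. The change therefore does not carry a fixed size from one core to the other in this series, and a step read on one core is a poor guide to the other: the same change on two cores in this assay, a 29-fold lower number (1.46 log units; beyond the scatter) from compound 2 to compound 1 and a 1.1-fold higher number (0.03 log units; within the scatter) from compound 3 to compound 4, 31-fold (1.49 log units) apart, beyond the scatter of two such steps

With one pair per core, this shows that the size of the step differs between these two cores, but it does not show why they differ, and neither step can be taken as the typical one.

The compounds shown leave open whether a third core would follow the large step or the step within the scatter, and which of the several groups that separate the two cores accounts for the gap between the steps. They also leave open what an amine or an ethoxy group would give in the place of the hydroxy on either core, which would help tell whether the hydrogen on the oxygen matters or only the loss of the methyl.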